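A few compounds are considered here, and "the series" means these few. Any claim that something is new, unique, unknown or untested is made for them only; others in the source may bear on it.

In a functional assay on HEK293 cells (Homo sapiens) for cytotoxicity (a higher number here means that more compound is tolerated, a lower number that less compound is tolerated), compound 1 `COc1ccc([C@H]2CC(=O)N(c3cccc(NCCCc4ccccc4)c3)C2)cc1OC1CCCC1` gives only a limit, > 10000 nM. Within the data shown here, compound 2 `COc1ccc(OC)c(S(=O)(=O)Nc2cccc(N3C[C@@H](c4ccc(OC)c(OC5CCCC5)c4)CC3=O)c2)c1` gives 7590 nM, the only actual number so far in this assay. Compound 3 `COc1ccc([C@H]2CC(=O)N(c3cccc(NS(=O)(=O)c4cccc(F)c4)c3)C2)cc1OC1CCCC1` has 3-fluorophenyl in place of 2,5-dimethoxyphenyl on a sulfonyl sulfur. Among the measured compounds shown here, no measured pair shows what such a change does, so no shift beyond the scatter is expected in this assay. The estimated move is a 1.2-fold higher number from compound 2 to compound 3 (0.07 log units; within the scatter). For compound 3 the expected value is 9000 nM, with an estimated range from 4000 nM to 20000 nM.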

Compound 3, half-maximal cytotoxic concentration: > 10000 nM
Compound 3: only a limit was reported; the forecaster's own chance of this, stated with the estimate: 45%; at least 1.1-fold (0.04 log units) between middle value and limit.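

In this assay, 3-fluorophenyl in place of 2,5-dimethoxyphenyl on a sulfonyl sulfur gives an at least 1.3-fold higher number from compound 2 to compound 3 (0.11 log units; that floor lies within the scatter), so the first step read at this position shows no shift beyond the scatter. Going by these compounds, the value of compound 3 is only a limit, so the true size of this step remains unknown. Compound 1 and compound 3 both give limits, and the step between them cannot be read. It remains open whether an amine or a carboxylic acid in place of 3-fluorophenyl on a sulfonyl sulfur would give a readable number rather than another limit: the limit of > 10000 nM in this assay, at which 2 of the 3 values shown sit.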